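The compounds below may be only part of what the source reports. "The series", "measured", "known", "first", "only" and "open" are said of these compounds alone.

Compound 1 `c1ccc(CO/N=C2/C(c3c[nH]c4ccccc34)=Nc3ccccc32)cc1` gives 22000 nM; compound 2 `Fc1ccc2c(c1)/C(=N\OCc1ccccc1)C(c1c[nH]c3ccc(F)cc13)=N2` gives 12000 nM; compound 3 `Cc1ccc(CO/N=C2/C(c3c[nH]c4ccccc34)=Nc3ccccc32)cc1` gives 29800 nM. All three were measured in a functional assay on NCI-H460 cells (Homo sapiens) for cytotoxicity, read by MTT assay, with a stated time of 2 days; on this read-out higher numbers stand for weaker inhibition and lower numbers for stronger inhibition.

Compound 3 differs from compound 1 by methyl in place of hydrogen on an aromatic carbon, and that step was a 1.4-fold higher number from compound 1 to compound 3 (0.13 log units; within the scatter). Compound 2 shares much with compound 1, but the difference between the two cores is not broken down here. Compound 4 `Cc1ccc(CO/N=C2/C(c3c[nH]c4ccc(F)cc34)=Nc3ccc(F)cc32)cc1` is not yet measured; it differs from compound 2 by methyl in place of hydrogen on an aromatic carbon, the same change as that from compound 1 to compound 3, at the same place in the same words.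

Because the earlier step was a 1.4-fold higher number from compound 1 to compound 3 (0.13 log units; within the scatter), the step from compound 2 to compound 4 is expected to be a 1.3-fold higher number from compound 2 to compound 4 (0.12 log units; within the scatter). On that basis compound 4 is estimated to give 16000 nM in this assay, with a range from 8000 nM to 32000 nM.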

Compound 4, half-maximal inhibitory concentration: 12000 nM
For compound 4 the middle estimate is 1.3-fold (0.12 log units) above the measured one, within the range that was stated.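

In this assay, methyl in place of hydrogen on an aromatic carbon gave no change at the digits printed from compound 2 to compound 4 (within the scatter), and this step does not differ from the one on the core of compound 1: the same change on two cores in this assay, a 1.4-fold higher number (0.13 log units; within the scatter) from compound 1 to compound 3 and no change at the digits printed (within the scatter) from compound 2 to compound 4, 1.4-fold (0.13 log units) apart, within the scatter of two such steps. On both cores shown, going from benzyl to 4-methylbenzyl therefore leaves the number within the scatter, so the change carries across these two cores as a step too small to read. This does not give the step a direction or size of its own, and two cores cannot show how it would behave on a third.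

The compounds shown leave open whether an amine or a carboxylic acid in place of that methyl would move the number beyond the scatter. They also leave open what a longer chain at that place would do.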